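From Carboxy to Carbamoyl: Compound 3 to Compound 4

This account rests on a few compounds, and the source may have more. Where it says the series, first, only, none or still open, it means among the compounds named here.

Compound 1 `O=C(CCCCCc1ccc(Br)cc1)N1CCOC1=O` gives 8510 nM in an assay on HEK293 cells for inhibition of N-acylethanolamine-hydrolyzing acid amidase (Rattus norvegicus), read by LC-MS, with a stated time of 30 min; a higher number here means a weaker inhibitor, a lower number a stronger inhibitor.
Compound 2 `O=C(CCCCCc1ccc(CO)cc1)N1CCOC1=O` gives 190 nM in this assay.
Compound 3 `O=C(O)c1ccc(CCCCCC(=O)N2CCOC2=O)cc1` is reported only as a limit of > 20000 nM in this assay.

Compound 3 stands at the weak end of the three: its value is a limit of the assay and not a number, so its true position is open (the limit of > 20000 nM in this assay, at which 1 of the 3 values shown sits). Among the measured steps, the change from hydroxymethyl to carboxy, an at least 100-fold higher number from compound 2 to compound 3 (2.02 log units; beyond the scatter), and the change from bromo to carboxy, an at least 2.3-fold higher number from compound 1 to compound 3 (0.37 log units; beyond the scatter), both bear on compound 3 and both ran toward weaker inhibition.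

Compound 4 `NC(=O)c1ccc(CCCCCC(=O)N2CCOC2=O)cc1` differs from compound 3 by amino in place of hydroxy on a carbonyl carbon. Within the data shown here, no measured step swaps hydroxy for amino on a carbonyl carbon, so the measured steps bear on it only through compound 3 itself, whose value is a limit. Because the two steps ending at compound 3 were an at least 100-fold higher number from compound 2 to compound 3 (2.02 log units; beyond the scatter) and an at least 2.3-fold higher number from compound 1 to compound 3 (0.37 log units; beyond the scatter), compound 4 is expected not to return to the potency of compound 2. Compound 4 is estimated at 12000 nM, between 2500 nM and 40000 nM, a change of an at least 1.6-fold lower number from compound 3 to compound 4 (0.22 log units; that floor lies within the scatter) that is expected to be at most modest and may again give only a limit.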

Compound 4, half-maximal inhibitory concentration: > 20000 nM
Compound 4 was reported as a limit; the forecaster's own chance of this, stated with the estimate: 40%; middle value at least 1.6-fold (0.22 log units) from the limit.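

In this assay compound 4 gives only a limit of > 20000 nM, and compound 3 stands at that same limit, so the change of hydroxy to amino on a carbonyl carbon cannot be read and nothing orders the two compounds. What compound 4 adds is that carbamoyl, like carboxy, leaves the series far from the hydroxymethyl compound, with an at least 100-fold higher number from compound 2 to compound 4 (2.02 log units; beyond the scatter), and that it also falls short of the bromo compound, with an at least 2.3-fold higher number from compound 1 to compound 4 (0.37 log units; beyond the scatter). Hydroxymethyl is thus still the only group shown at this place that reaches a potency near the level of compound 2, and the weak end of the series now holds a second compound: the limit of > 20000 nM in this assay, at which 2 of the 4 values shown sit.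

As far as these compounds go, how weak compound 3 and compound 4 really are, and whether carboxy and carbamoyl differ at all, stays open in this assay. From the compounds shown here alone, it also stays open whether a methoxymethyl group, an aminomethyl group or a longer hydroxyalkyl chain on the aromatic carbon would keep the value of compound 2 at 190 nM or lose it.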